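A few compounds are considered here, and "the series" means these few. Any claim that something is new, unique, unknown or untested is made for them only; others in the source may bear on it.

Compound 1 `Oc1cccc(-c2cc(-c3ccccc3)cc(-c3cccs3)n2)c1`: 18100 nM. Compound 2 `Oc1ccc(-c2cc(-c3ccccc3)cc(-c3cccs3)n2)cc1`: 2400 nM. Compound 3 `Oc1cccc(-c2cc(-c3ccccc3)nc(-c3ccco3)c2)c1`: 20800 nM.

All three were tested in a functional assay on MDA-MB-231 cells (Homo sapiens) for cytotoxicity, read by ELISA, with a stated time of 2 days; a lower number here means a stronger inhibitor, a higher number a weaker inhibitor. Compound 1 gives 18100 nM and compound 2 gives 2400 nM, a step of a 7.5-fold lower number from compound 1 to compound 2 (0.88 log units; beyond the scatter); the change behind it is 4-hydroxyphenyl in place of 3-hydroxyphenyl on an aromatic carbon. Compound 3 gives 20800 nM. The difference between the cores of compound 1 and compound 3 is not broken down here, and their two values lie within the scatter of each other.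

Compound 4 `Oc1ccc(-c2cc(-c3ccccc3)nc(-c3ccco3)c2)cc1` has not been measured. It differs from compound 3 by 4-hydroxyphenyl in place of 3-hydroxyphenyl on an aromatic carbon, the same kind of change as that seen earlier, though here the group sits opposite the ring nitrogen and meta to a furan-2-yl group, rather than next to the ring nitrogen and meta to a thiophen-2-yl group. Because the earlier step was a 7.5-fold lower number from compound 1 to compound 2 (0.88 log units; beyond the scatter), a step in the same direction but of less certain size is expected, a 5.2-fold lower number from compound 3 to compound 4 (0.72 log units; beyond the scatter). Compound 4 is accordingly estimated at 4000 nM, with a likely range from 1500 nM to 12000 nM.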

Compound 4, half-maximal inhibitory concentration: 1000 nM
Estimate against measurement, compound 4: 4.0-fold (0.60 log units) above; measured number below the stated range.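

In this assay, 4-hydroxyphenyl in place of 3-hydroxyphenyl again gives a lower number on the second core, with a 21-fold lower number from compound 3 to compound 4 (1.32 log units; beyond the scatter), so the direction of the change carries across the two cores. Within the data shown here, its size does not carry over unchanged: the same change on two cores in this assay, a 7.5-fold lower number (0.88 log units; beyond the scatter) from compound 1 to compound 2 and a 21-fold lower number (1.32 log units; beyond the scatter) from compound 3 to compound 4, 2.8-fold (0.44 log units) apart, beyond the scatter of two such steps With only two cores, this does not show which difference between them goes with the gap, or whether the direction would hold on a further core.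

Going by these compounds, whether a methoxy group, an amine or a carboxylic acid in place of the hydroxyl on that phenyl ring would keep the lower number remains open. So does the effect of furan-2-yl in place of thiophen-2-yl on an otherwise unchanged core.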